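A few compounds are considered here, and "the series" means these few. Any claim that something is new, unique, unknown or untested is made for them only; others in the source may bear on it.

Compound 3 `COc1cccc(CNCCCNc2ccnc3cc(-c4ccccc4)ccc23)c1O` gives 237 10^-6 cm/s in an ADME assay for permeability, using PAMPA, with a stated time of 30 min, at pH 7.4; on this read-out higher numbers stand for higher permeability and lower numbers for lower permeability. On the three numbers measured it stands second highest: compound 2 `Clc1ccc(Oc2ccc3c(NCCCNCc4ccco4)ccnc3c2)cc1` gives 317 10^-6 cm/s, a difference within the scatter, while compound 1 `COc1cccc(CNCCCNc2ccnc3cc(Cc4ccc(F)cc4)ccc23)c1O` gives 23 10^-6 cm/s, well below. Among the measured compounds shown here, the only single-point step measured is a 10-fold higher number from compound 1 to compound 3 (1.01 log units; beyond the scatter), beyond the scatter.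

Compound 4 `COc1cccc(CNCCCNc2ccnc3cc(Oc4ccc(Cl)cc4)ccc23)c1O` differs from compound 3 in one place: 4-chlorophenoxy in place of phenyl on an aromatic carbon. For the measured compounds named here, no measured step carries this same exchange. The step of a 10-fold higher number from compound 1 to compound 3 (1.01 log units; beyond the scatter) alters the same position but swaps a different pair of groups, so it bears only loosely on the present change. Compound 2 carries the entering 4-chlorophenoxy group at this position, with a different amine end, and gives 317 10^-6 cm/s. Compound 3, with phenyl there, gives 237 10^-6 cm/s, and the two values lie within the scatter of each other. The expected step is therefore a 1.1-fold higher number from compound 3 to compound 4 (0.04 log units; within the scatter), no more than the scatter. Compound 4 is estimated at 260 10^-6 cm/s in this assay, with a range from 120 10^-6 cm/s to 520 10^-6 cm/s.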

Compound 4, apparent permeability: 317 10^-6 cm/s
Compound 4: middle estimate off by 1.2-fold (0.09 log units), on the low side, and the stated range covers the measured number.
By their numbers in this assay, from the lowest: compound 1; then compounds 3, 2 and 4 (each within the scatter of the next).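

On this aromatic carbon, 4-chlorophenoxy in place of phenyl gives a 1.3-fold higher number from compound 3 to compound 4 (0.13 log units; within the scatter) in this assay and so leaves the read-out within the scatter despite the added oxygen and chlorine. Against 4-fluorobenzyl at the same place, the exchange gives a 14-fold higher number from compound 1 to compound 4 (1.14 log units; beyond the scatter) and thus extends the large gap to a second group, so among the three groups shown here only 4-fluorobenzyl stands apart. With 4-chlorophenoxy held fixed, 2-hydroxy-3-methoxyphenyl in place of furan-2-yl on the saturated chain carbon bound to an amine nitrogen gives no change at the digits printed from compound 2 to compound 4 (within the scatter) as the step, which shows no separation between these two amine ends.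

Nothing available explains any of these steps. Still open, from the compounds shown here alone, is whether a directly attached amine or a carboxylic acid on this aromatic carbon would stay with phenyl and 4-chlorophenoxy or fall with 4-fluorobenzyl.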